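Phenyl for Methyl: Expected Edema Inhibition of Compound 4

A few compounds are considered here, and "the series" means these few. Any claim that something is new, unique, unknown or untested is made for them only; others in the source may bear on it.

Measured compounds:
Compound 1 `CCOC(=O)c1nn(-c2ccccc2)c(-c2ccc(OC)cc2OC)c1-c1ccccc1` gives 17.7% in a functional assay on the whole organism (strain albino) for inhibition, with Rattus norvegicus as the target, read by paw edema, with stated times of 30 min and 1 h, at a dose of 25 mg/kg by the intraperitoneal route; a higher number here means more inhibition at the dose given (going by the name of the read-out), a lower number less inhibition.
Compound 2 `CCOC(=O)c1nn(-c2ccccc2)c(-c2ccc(OC)cc2OC)c1C` gives 4.9% in this assay.
Compound 3 `COc1ccc(-c2c(C)c(C(=O)O)nn2-c2ccc(Cl)cc2)c(OC)c1` gives 24.7% in this assay.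

Compound 3 and compound 1 lie within the scatter of each other, while compound 2 lies beyond it from both. Compound 2 and compound 1 differ by phenyl in place of methyl on an aromatic carbon, a step of a number 12.8 percentage points higher from compound 2 to compound 1 (beyond the scatter). Compound 4 `COc1ccc(-c2c(-c3ccccc3)c(C(=O)O)nn2-c2ccc(Cl)cc2)c(OC)c1` is not yet measured; it differs from compound 3 by phenyl in place of methyl on an aromatic carbon. This is the same kind of change, though here the place is next to the ring atom that bears a carboxy group and two ring bonds from the ring atom that bears a 4-chlorophenyl group, rather than next to the ring atom that bears an ethoxycarbonyl group and two ring bonds from the ring atom that bears a phenyl group. The difference between the cores of compound 3 and compound 2 is not broken down here. Compound 4 is expected to give 37%, from 24% to 50%, a step of a number 12.3 percentage points higher from compound 3 to compound 4 (beyond the scatter), because the same kind of change gave a number 12.8 percentage points higher from compound 2 to compound 1 (beyond the scatter).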

Compound 4, a percentage reported as inhibition, in the whole organism at one dose (the size of the read-out at that dose, not a potency): 37%
The estimate for compound 4 equals the measured number at the digits printed, within the range that was stated.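

On the core of compound 3, phenyl in place of methyl on an aromatic carbon gave a number 12.3 percentage points higher from compound 3 to compound 4 (beyond the scatter). In this assay, among these compounds, the change carried over from one core to the other with much the same size: the same change on two cores in this assay, a number 12.8 percentage points higher (beyond the scatter) from compound 2 to compound 1 and a number 12.3 percentage points higher (beyond the scatter) from compound 3 to compound 4, 0.5 percentage points apart, within the scatter of two such steps This rests on only two pairs, read at a single dose, so it does not show that the step would hold on other cores, nor does it say anything about potency.

The compounds shown leave open what a longer chain or an amine would give in place of the phenyl at this carbon. Among the compounds shown here, they also leave open how the ethoxycarbonyl and carboxy groups each contribute on their own, as no pair here isolates that exchange.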